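The compounds below may be only part of what the source reports. "The series", "measured", "known", "first", "only" and "open" are said of these compounds alone.

Of the compounds shown here, three of this set have been tested in a functional assay on MIA PaCa-2 cells (Homo sapiens) for cytotoxicity, read by luminescence, with a stated time of 72 h, in the presence of a further agent that is not named here; a higher number here means a weaker inhibitor, a lower number a stronger inhibitor. Compound 1 `CNC(=S)N/N=C/c1nccc2ccccc12` gives 331 nM. Compound 2 `CNC(=S)N/N=C/c1ncc(F)c2ccccc12`, which carries fluoro in place of hydrogen on an aromatic carbon, gives 114 nM, and compound 3 `CNC(=S)NN=Cc1nccc2c(NC)cccc12` gives 607 nM. Compound 2 thus holds the lowest number of the three: the step of a 2.9-fold lower number from compound 1 to compound 2 (0.46 log units; beyond the scatter) is beyond the scatter, and compound 3 lies further off still. The next compound, compound 4 `NC(=S)N/N=C/c1ncc(F)c2ccccc12`, differs from compound 2 only by hydrogen in place of methyl on an amide-type nitrogen, that is, methylamino to amino. Within the data shown here, none of the measured steps touches this nitrogen; the only step in hand, a 2.9-fold lower number from compound 1 to compound 2 (0.46 log units; beyond the scatter), concerns an aromatic carbon and says nothing about what sits on the amide-type nitrogen. Among the measured compounds shown here, with no step bearing on the change, a shift of about a 1.6-fold higher number from compound 2 to compound 4 (0.20 log units; within the scatter) in this assay is expected, not clearly beyond the scatter in either direction. Compound 4 is therefore estimated at 180 nM, with a range from 70 nM to 500 nM.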

Compound 4, half-maximal inhibitory concentration: 2060 nM
Compound 4: the middle estimate sits 11-fold (1.06 log units) below what was measured; measured number above the stated range.
By their numbers in this assay, from the lowest: compound 2; then compounds 1 and 3 (each within the scatter of the next); then compound 4.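

In this assay, among these compounds, the methyl on the amide-type nitrogen proves to matter a great deal: replacing it with hydrogen gives an 18-fold higher number from compound 2 to compound 4 (1.26 log units; beyond the scatter), a large step, whereas the only earlier step, a 2.9-fold lower number from compound 1 to compound 2 (0.46 log units; beyond the scatter), was modest and concerned an aromatic carbon. Among the compounds shown here, the result therefore shows that this nitrogen, which no earlier step touched, is a sensitive position, where the loss of a single carbon separates compound 2 from compound 4 by far more than the scatter. Nothing available here accounts for the size of this step. From the compounds shown here alone, it remains open whether ethyl, a longer chain or a second methyl on this nitrogen would hold, lower or raise the number. Going by these compounds, it is also open whether methylamino to amino has a similar effect on the core of compound 1, without the fluoro.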